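This account rests on a few compounds, and the source may have more. Where it says the series, first, only, none or still open, it means among the compounds named here.

Compound 1 `CC(C)[C@H](NC(=O)COc1cccc2ccccc12)C(=O)N[C@@H](CC(=O)O)C(=O)COC(=O)c1c(Cl)cccc1Cl`: 11500 nM
Compound 2 `CC(C)[C@H](NC(=O)COc1cccc2ccccc12)C(=O)N[C@@H](CC(=O)O)C(=O)COc1c(F)c(F)cc(F)c1F`: 6250 nM

In a functional assay with Homo sapiens as the target (a lower number here means a stronger inhibitor, a higher number a weaker inhibitor), compound 2 gives 6250 nM, and compound 1 gives 11500 nM. Among the compounds with values here, the only measured step, a 1.8-fold lower number from compound 1 to compound 2 (0.26 log units; within the scatter), lies within the usual scatter, so these two values cannot be told apart.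

Compound 3 `CC(C)[C@H](NC(=O)COc1cccc2ccccc12)C(=O)N[C@@H](CC(=O)O)C(=O)COc1ccc([N+](=O)[O-])cc1F` keeps the core of compound 2 and changes a single group: 2-fluoro-4-nitrophenyl in place of 2,3,5,6-tetrafluorophenyl on an oxygen on a saturated carbon. It has 2-fluoro-4-nitrophenyl in place of 2,3,5,6-tetrafluorophenyl, on an oxygen on a saturated carbon.

Within the data shown here, the one measured step, a 1.8-fold lower number from compound 1 to compound 2 (0.26 log units; within the scatter), also exchanged the group at this place and stayed within the scatter. Among the measured compounds shown here, that makes it the only guide, and a thin one, as no measured compound carries 2-fluoro-4-nitrophenyl. No change beyond the scatter is therefore expected in this assay. The expected step is a 1.1-fold higher number from compound 2 to compound 3 (0.05 log units; within the scatter). For compound 3 the estimate is 7000 nM, with an expected range from 2500 nM to 20000 nM.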

Compound 3, half-maximal inhibitory concentration: 15800 nM
Compound 3: the middle estimate sits 2.3-fold (0.35 log units) below what was measured; low and high end bracket the measured number.
By their numbers in this assay, from the lowest: compounds 2, 1 and 3 (each within the scatter of the next, the first and the last beyond it).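

In this assay, within the data shown here, the group on this oxygen does make a modest difference: 2-fluoro-4-nitrophenyl in place of 2,3,5,6-tetrafluorophenyl gives a 2.5-fold higher number from compound 2 to compound 3 (0.40 log units; beyond the scatter), the first step here that lies beyond the scatter. Set against the (2,6-dichlorophenyl)carbonyl group, the same entering group gives a 1.4-fold higher number from compound 1 to compound 3 (0.14 log units; within the scatter), so compound 1 and compound 3 cannot be told apart, and only compound 2 and compound 3 are separated. No measurement available here says why the number rises.

The nitro group and the loss of three fluorines arrive together in this step, so the compounds shown cannot assign the rise to either one. A plain phenyl or a 4-nitrophenyl on the same oxygen would help to pull these two changes apart.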